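A few compounds are considered here, and "the series" means these few. Any claim that something is new, unique, unknown or untested is made for them only; others in the source may bear on it.

Measured compounds:
compound 1, `C#CCN(Cc1ccc(OCc2cccc(F)c2)cc1)[C@@H](C)C(N)=O`: 530 nM
compound 2, `C[C@H](NCc1ccc(OCc2cccc(F)c2)cc1Cl)C(N)=O`: 28 nM

Of the compounds shown here, two have been tested in an assay on Sf9 cells for inhibition of Amine oxidase [flavin-containing] B (Homo sapiens), with stated times of 15 min and 60 min; on this read-out higher numbers stand for weaker inhibition and lower numbers for stronger inhibition. Compound 1 gives 530 nM, and compound 2 gives 28 nM. Of these two numbers, compound 2 holds the lower one, and the gap to compound 1 lies beyond the usual scatter of repeated measurements. Compound 1 and compound 2 differ in more than one place, so their two values alone show no single change at work.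

The unmeasured compound 3, `C#CCN(Cc1ccc(OCc2cccc(F)c2)cc1Cl)[C@@H](C)C(N)=O`, is derived from compound 2 by a single change: propargyl in place of hydrogen on an amine nitrogen. For the measured compounds named here, no measured pair shows this change on its own, so its effect here is unknown. Compound 1 also carries a propargyl on its amine nitrogen and gives the higher number, but it lacks the chlorine of compound 2, so that comparison is not clean. In this assay compound 3 is expected to give about 50 nM, with a likely range of 10 nM to 400 nM. The expected step is a 1.8-fold higher number from compound 2 to compound 3 (0.25 log units; within the scatter), which is modest and uncertain in direction.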

Compound 3, half-maximal inhibitory concentration: 68 nM
Estimate against measurement, compound 3: 1.4-fold (0.13 log units) below; the measured number falls inside the stated range.
By their numbers in this assay, from the lowest: compound 2; then compound 3; then compound 1.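

In this assay, putting propargyl in place of hydrogen on the amine nitrogen, with the chloro group kept, gives a 2.4-fold higher number from compound 2 to compound 3 (0.39 log units; beyond the scatter) and so shows on its own that this nitrogen accepts the group at a modest loss of inhibition. With propargyl kept, chloro in place of hydrogen on an aromatic carbon gives a 7.8-fold lower number from compound 1 to compound 3 (0.89 log units; beyond the scatter). This separates the two changes that were mixed between compound 1 and compound 2, showing that they move the number in opposite directions. No supporting measurement accounts for either step.

Going by these compounds, whether a methyl group or a longer chain such as butyl on the same nitrogen would give a similar step remains open. On these data alone, it is equally open whether bromo or methoxy on that aromatic carbon would match the chloro group.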